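The compounds below may be only part of what the source reports. "The series", "measured", "known", "first", "only" and "open" are said of these compounds alone.

Compound 3 `COc1cc(C(=O)N(C)C)ccc1Nc1nc(O[C@H]2CCOC(C)(C)C2)c2cc[nH]c2n1` is the reference point here. In a functional assay on CAL-51 cells (Homo sapiens) for antiproliferative activity, read by luminescence and CellTiter-Glo, with a stated time of 3 days (on this read-out higher numbers stand for weaker inhibition and lower numbers for stronger inhibition), compound 3 gives 131 nM, the second highest of three numbers, alongside compound 1 `COc1cc(N2CCC(C)(O)CC2)ccc1Nc1nc(O[C@H]2CCOC(C)(C)C2)c2cc[nH]c2n1` at 71 nM and compound 2 `COc1cc(C(=O)N(C)C)ccc1Nc1nc(OC2CCCCC2)c2cc[nH]c2n1` at 190 nM. Its gaps to both lie within the scatter.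

Compound 4 `COc1cc(N2CCN(C3COC3)CC2)ccc1Nc1nc(O[C@H]2CCOC(C)(C)C2)c2cc[nH]c2n1` differs from compound 3 in one place: 4-(oxetan-3-yl)piperazin-1-yl in place of dimethylcarbamoyl on an aromatic carbon. The group that leaves is the dimethylcarbamoyl, and the 4-(oxetan-3-yl)piperazin-1-yl takes its position on the aromatic carbon.

The most relevant measured change is a 1.8-fold higher number from compound 1 to compound 3 (0.27 log units; within the scatter). It involves the same aromatic carbon and the same dimethylcarbamoyl. Read in reverse, it points to a lower number when dimethylcarbamoyl gives way to a larger group, although it lies within the scatter. The other change, a 1.5-fold lower number from compound 2 to compound 3 (0.16 log units; within the scatter), concerns the group on an oxygen, a part left untouched here, so it says little about this swap.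

Going by the values given here, compound 1 carries a different group from the one entering compound 4, and a single step within the scatter is thin evidence. Only a modest drift towards a lower number is therefore expected in this assay, probably no larger than the scatter. The expected change is an estimated 1.6-fold lower number from compound 3 to compound 4 (0.21 log units; within the scatter) in this read-out.

Compound 4 is estimated at 80 nM, with an expected range from 30 nM to 200 nM.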

Compound 4, half-maximal inhibitory concentration: 84 nM
Compound 4: the middle estimate sits 1.1-fold (0.02 log units) below what was measured; the measured number falls inside the stated range.
By their numbers in this assay, from the lowest: compounds 1, 4, 3 and 2 (each within the scatter of the next, the first and the last beyond it).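

In this assay, this aromatic carbon accepts the 4-(oxetan-3-yl)piperazin-1-yl, with 10 heavy atoms and two non-aromatic rings, in place of the dimethylcarbamoyl, with 5 heavy atoms and no ring, and the result is a 1.6-fold lower number from compound 3 to compound 4 (0.19 log units; within the scatter). Compared with the 4-hydroxy-4-methylpiperidin-1-yl on the same carbon, the new group gives a 1.2-fold higher number from compound 1 to compound 4 (0.07 log units; within the scatter), so all three groups now tested at this position, in compounds 1, 3 and 4, lie within the scatter of one another, and this read-out does not separate them despite their different sizes and shapes. Nothing measured here accounts for how closely these groups agree.

Whether the oxetan-3-yl contributes anything on its own would take a comparison with a 4-methylpiperazin-1-yl on the same carbon, with the rest of the molecule unchanged. Also open, going by these compounds, is how far this tolerance extends, for instance to a carboxylic acid or a primary amine on this carbon, and whether the swap reads the same with cyclohexyl in place of 2,2-dimethyloxan-4-yl on the oxygen.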